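Benzyl methyl placement in the amide series

The source may hold more compounds than are shown below. What is called first, only, known or untested is meant among the compounds shown, and "the series" means these compounds.

Three members of the series have been measured in a functional assay on CHO cells for positive allosteric modulation of muscarinic acetylcholine receptor M5 (Homo sapiens), read by calcium flux; a higher number here means a larger maximal response, a lower number a smaller maximal response. Compound 1 `CCN(C(=O)C1CCN(S(=O)(=O)c2ccc3cn[nH]c3c2)CC1)[C@H](C)c1ccccc1` reaches 87%. Compound 2 `CCN(Cc1cccc(Cl)c1)C(=O)C1CCN(S(=O)(=O)c2ccc3cn[nH]c3c2)CC1` gives 77%, and compound 3 `CCN(Cc1cccc(C)c1)C(=O)C1CCN(S(=O)(=O)c2ccc3cn[nH]c3c2)CC1` gives 78%. The steps are a number 10 percentage points lower from compound 1 to compound 2 (within the scatter), a number 9 percentage points lower from compound 1 to compound 3 (within the scatter) and a number 1 percentage points higher from compound 2 to compound 3 (within the scatter); every one of them lies within the scatter, so compound 3 cannot be separated from compound 2 or compound 1 on these numbers, and its value sits between those two.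

Compound 4 `CCN(Cc1ccccc1C)C(=O)C1CCN(S(=O)(=O)c2ccc3cn[nH]c3c2)CC1` differs from compound 3 only in 2-methylphenyl in place of 3-methylphenyl on a saturated chain carbon bound to an amide-type nitrogen. Within the data shown here, no measured step moves a methyl around the same ring. The nearest comparisons are the exchange of chloro for methyl on that ring, which gave a number 1 percentage points higher from compound 2 to compound 3 (within the scatter), and the exchange of the whole benzyl for 1-phenylethyl, which gave a number 9 percentage points lower from compound 1 to compound 3 (within the scatter); neither left the scatter. Nothing here points to a step beyond the scatter in this assay, so compound 4 is expected to lie close to compound 3, with an estimated step of no change at the digits printed from compound 3 to compound 4 (within the scatter). The estimate for compound 4 is 78%, with a range of 65% to 90%.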

Compound 4, largest response reached (reported as percent of maximum), in percent of the reference or control that the assay uses: 103%
For compound 4 the middle estimate is 25 percentage points below the measured one, and the stated range ends below it.
By their numbers in this assay, from the lowest: compounds 2, 3 and 1 (each within the scatter of the next); then compound 4.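

In this assay the placement of the methyl on this ring carries weight that the earlier exchanges did not reveal: 2-methylphenyl in place of 3-methylphenyl gives a number 25 percentage points higher from compound 3 to compound 4 (beyond the scatter) even though the two compounds have the same atoms. Among these compounds, the same group also stands clear of the other two amides, with a number 26 percentage points higher from compound 2 to compound 4 (beyond the scatter) and a number 16 percentage points higher from compound 1 to compound 4 (beyond the scatter) on record, so compound 4 is the only member whose steps to all others lie beyond the scatter. Nothing available bears on why this change goes with a larger maximal response.

Still open, from the compounds shown here alone, is whether the gain belongs to the methyl itself or would persist with ethyl, methoxy or fluoro in its place on the 2-methylphenyl ring. Also open, going by these compounds, is whether a 1-(2-methylphenyl)ethyl group on the amide nitrogen would keep it.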